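Fluoro to Chloro on the Phenylamino Group

The source may report more compounds than this note shows. Statements on the series, on what has been measured and on what is new or still open speak of the compounds shown alone.

Compound 1, `CC(C)c1ccc(-c2nc(SCc3cn(CC(=O)NC(=O)Nc4ccccn4)nn3)nc(Nc3ccccc3Cl)c2C#N)cc1`: 43700 nM
Compound 2, `CC(C)c1ccc(-c2nc(SCc3cn(CC(=O)NC(=O)Nc4ccccn4)nn3)nc(Nc3ccc(F)cc3)c2C#N)cc1`: > 64000 nM

In a functional assay on MCF7 cells (Homo sapiens) for inhibition, read by MTT assay, with a stated time of 72 h (on this read-out lower numbers stand for stronger inhibition and higher numbers for weaker inhibition), compound 1 gives 43700 nM. For compound 2 this assay reports only a limit, > 64000 nM, so its true number is not known. Among the measured compounds shown here, the single measured step, an at least 1.4-fold higher number from compound 1 to compound 2 (0.16 log units; that floor lies within the scatter), therefore has only a floor, and that floor lies within the scatter. Compound 3, `CC(C)c1ccc(-c2nc(SCc3cn(CC(=O)NC(=O)Nc4ccccn4)nn3)nc(Nc3ccc(Cl)cc3)c2C#N)cc1`, differs from compound 2 by chloro in place of fluoro on an aromatic carbon. For the measured compounds named here, no measured step exchanges fluoro for chloro at this place; the one step available, an at least 1.4-fold higher number from compound 1 to compound 2 (0.16 log units; that floor lies within the scatter), moves a different substituent, so it gives little guidance. Because (the limit of > 64000 nM in this assay, at which 1 of the 2 values shown sits), the starting point itself is a limit. The step from compound 2 to compound 3 is expected to stay within the scatter, as an at least 1.0-fold lower number from compound 2 to compound 3 (0.02 log units; that floor lies within the scatter). Compound 3 is estimated at 60000 nM, between 30000 nM and 130000 nM, and a limit rather than a number is a real possibility.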

Compound 3, half-maximal inhibitory concentration: > 64000 nM
Compound 3: no number, only a limit; the forecaster's own chance of this, stated with the estimate: 55%; middle value at least 1.0-fold (0.02 log units) from the limit.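

Compound 3, like compound 2, gives only a limit in this assay and no number, so chloro at this place, para to a large group, does not bring a readable value. The exchange of 2-chlorophenyl for 4-chlorophenyl gives an at least 1.4-fold higher number from compound 1 to compound 3 (0.16 log units; that floor lies within the scatter) and so shows no real difference, as its floor does not pass the usual spread of repeat measurements. The step for fluoro to chloro cannot be read, because both of its values are limits: the limit of > 64000 nM in this assay, at which 2 of the 3 values shown sit.

The compounds shown leave open whether any group at this place gives a readable number in this assay beyond that of compound 1, for instance an amine or a methoxy group in place of the halogen. From the compounds shown here alone, how far the true numbers of compound 2 and compound 3 lie past their limits also stays open.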